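The source may hold more compounds than are shown below. What is called first, only, known or untested is meant among the compounds shown, and "the series" means these compounds.

Three compounds share one core and differ only in the group on the pendant aromatic ring. Compound 1 `O=C1CCCc2cc(OCc3cccc(I)c3)ccc21` carries iodo and in an assay on isolated protein for inhibition of Amine oxidase [flavin-containing] A (Homo sapiens), read by fluorescence and spectrophotometry, with a stated time of 30 min (on this read-out lower numbers stand for stronger inhibition and higher numbers for weaker inhibition), compound 1 gives 1290 nM. Compound 2 `Cc1ccc(COc2ccc3c(c2)CCCC3=O)cc1` carries methyl, and in this assay compound 2 gives 2090 nM, the highest number of the three; against compound 1 the difference is within the scatter, while compound 3 `N#Cc1cccc(COc2ccc3c(c2)CCCC3=O)c1`, which carries cyano and in this assay gives 24 nM, lies far from it. Going by the values given here, the one step measured in a single place, a 54-fold lower number from compound 1 to compound 3 (1.73 log units; beyond the scatter), shows what a change of the group on that ring can do.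

Compound 4 `O=C1CCCc2cc(OCc3ccc(C(F)(F)F)cc3)ccc21` has not been measured. It differs from compound 2 by trifluoromethyl in place of methyl on an aromatic carbon. The step from compound 1 to compound 3 bears on it only loosely: it swaps a different pair of groups at a different place on the ring, so its size is no direct guide. The expected step of a 3.0-fold lower number from compound 2 to compound 4 (0.48 log units; beyond the scatter) is therefore a moderate lowering with wide uncertainty. Compound 4 is expected to give about 700 nM in this assay, likely between 120 nM and 4000 nM.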

Compound 4, half-maximal inhibitory concentration: 547 nM
Estimate against measurement, compound 4: 1.3-fold (0.11 log units) above, and the stated range covers the measured number.
By their numbers in this assay, from the lowest: compound 3; then compound 4; then compounds 1 and 2 (each within the scatter of the next).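

Going by these compounds alone, on the aromatic carbon para to a large group, the change gives a 3.8-fold lower number from compound 2 to compound 4 (0.58 log units; beyond the scatter) in this assay, the first measured step at this position. It shows that the number here responds to the group on that carbon: trifluoromethyl in place of methyl moves it beyond the scatter, although this modest step is much smaller than a 54-fold lower number from compound 1 to compound 3 (1.73 log units; beyond the scatter), which involves a different pair of groups at a different place on the ring. No measurement offered here explains the lowering.

From the compounds shown here alone, it remains open whether cyano on this same carbon would bring the number as low as in compound 3, or whether trifluoromethyl would do better at the place that cyano holds there. Going by these compounds, how an amine or a carboxylic acid would read on this carbon also remains open.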